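The source may report more compounds than this note shows. Statements on the series, on what has been measured and on what is new or still open speak of the compounds shown alone.

Measured compounds in a functional assay on the whole organism with Mus musculus as the target; on this read-out higher numbers stand for an effect only at larger amounts of compound and lower numbers for an effect already at smaller amounts:
- compound 1 `CCn1c(=O)[nH]c2c(ncn2C2O[C@H](CO)[C@@H](O)[C@H]2O)c1=N`: > 100 mg/kg (a limit)
- compound 2 `N=c1c2ncn(C3O[C@H](CO)[C@@H](O)[C@H]3O)c2[nH]c(=O)n1-c1ccccc1`: > 100 mg/kg (a limit)
- compound 3 `Cn1c(=O)[nH]c2c(nc(Br)n2C2O[C@H](CO)[C@@H](O)[C@H]2O)c1=N`: > 100 mg/kg (a limit)

For the measured compounds named here, the series has no numerical value so far. Compound 3 gives > 100 mg/kg, which is a limit and not a number. The other two values are limits as well, so compound 3 cannot be ranked against them, and the whole picture reduces to the limit of > 100 mg/kg in this assay, at which 3 of the 3 values shown sit.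

The next compound is compound 4 `Cn1c(=O)[nH]c2c(nc(N)n2C2O[C@H](CO)[C@@H](O)[C@H]2O)c1=N`, not yet measured. Its change is amino in place of bromo on an aromatic carbon.

Going by the values given here, only one measured step is available, a step that the two limits leave unreadable from compound 1 to compound 2, with phenyl in place of ethyl on an aromatic nitrogen. It has no readable size and concerns a different kind of ring atom, so it offers no size or direction to carry over. Among the compounds with values here, no measured step covers the exchange of bromo for amino.

With only the limit of > 100 mg/kg in this assay, at which 3 of the 3 values shown sit, to go on, no clear change is expected in this assay, and no direction is favoured. The expected step, a step that the limit leaves unreadable from compound 3 to compound 4, is therefore a rough estimate set against a limit. For compound 4 the estimate is 150 mg/kg, with an expected range of 50 mg/kg to 400 mg/kg.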

Compound 4, dose for half-maximal effect: > 100 mg/kg
Compound 4: no number, only a limit; the forecaster's own chance of this, stated with the estimate: 70%; the middle value lies beyond the limit too.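

No step can be read from compound 3 to compound 4 in this assay, as both values are limits and not numbers. The compounds shown leave open at what dose any of them has an effect, and whether any change to the shared core shifts that dose; the series so far rests on one limit: the limit of > 100 mg/kg in this assay, at which 4 of the 4 values shown sit.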